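Fluoro on the aromatic ring: expected half-life of compound 3

The source may hold more compounds than are shown below. What is called first, only, known or untested is meant among the compounds shown, and "the series" means these compounds.

Measured so far in an in vivo ADME assay on the whole organism (strain Sprague-Dawley) for metabolic stability, with Rattus norvegicus as the target; a higher number here means that the compound lasts longer, a lower number that the compound disappears faster:
- Compound 1 `O=C1[C@@H](NS(=O)(=O)c2ccc3cc(Cl)ccc3c2)CCN1c1ccc2c(c1)CCNC2`: 11 h
- Compound 2 `O=C1[C@@H](NS(=O)(=O)c2ccc3cc(Cl)ccc3c2)CCN1c1ccc2c(c1F)CCNC2`: 6.7 h

For the measured compounds named here, only two compounds have a number so far. Compound 1 therefore has a single neighbour for comparison, and the values of compound 1 and compound 2 lie within the scatter of each other.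

Compound 3 `O=C1[C@@H](NS(=O)(=O)c2ccc3cc(Cl)ccc3c2)CCN1c1cc2c(cc1F)CNCC2` has not yet been measured. Its difference from compound 1 is fluoro in place of hydrogen on an aromatic carbon, ortho to a large group, meta to a fused ring and para to a fused ring.

Compound 2 also carries fluoro in place of hydrogen on an aromatic carbon, but on a different carbon. It is therefore a useful guide, though not an exact one. That one measured step is a 1.6-fold lower number from compound 1 to compound 2 (0.22 log units; within the scatter). On this single step, no change beyond the scatter is expected in this assay, with at most a slight move towards a lower number.

The expected step is a 1.4-fold lower number from compound 1 to compound 3 (0.14 log units; within the scatter). The estimate for compound 3 is 8 h, with an expected range from 4 h to 15 h.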

Compound 3, half-life: 7.5 h
Compound 3: the middle estimate sits 1.1-fold (0.03 log units) above what was measured; the range from low to high includes it.
By their numbers in this assay, from the lowest: compounds 2, 3 and 1 (each within the scatter of the next).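

In this assay fluoro in place of hydrogen on this aromatic carbon, ortho to a large group, meta to a fused ring and para to a fused ring, gives a 1.5-fold lower number from compound 1 to compound 3 (0.17 log units; within the scatter) and so does not move the half-life beyond the usual scatter. Compound 2 carries fluoro on a different carbon of the same ring and gives a 1.6-fold lower number from compound 1 to compound 2 (0.22 log units; within the scatter) so, at both of these carbons, the new atom leaves the half-life within the scatter of compound 1. No further measurement is available to explain this result.

From the compounds shown here alone, it remains open whether a larger group on this carbon, such as methyl, methoxy or trifluoromethyl, or a group of a different kind, such as an amine or a carboxylic acid, would also leave the half-life within the scatter. The compounds shown also leave open what fluoro on both of these carbons at once would do, since each of the two steps changes only one carbon.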